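This account rests on a few compounds, and the source may have more. Where it says the series, first, only, none or still open, it means among the compounds named here.

Compound 1 (`CCCCC1([C@H](O)/C=C/C2CCC(=O)[C@@H]2CCCCCC(=O)O)CCC1`) 0.032 mg/kg
Compound 2 (`CCCCC1([C@H](O)/C=C/C2CCC(=O)[C@@H]2C/C=C\CCCC(=O)O)CCC1`) 0.00767 mg/kg
Compound 3 (`CCCCC1([C@H](O)/C=C/C2CCC(=O)[C@@H]2CCCCSCC(=O)O)CCC1`) not yet measured

In a functional assay on the whole organism (strain Hartley) for inhibition, with Cavia porcellus as the target, with stated times of 15 min and 2 min (on this read-out lower numbers stand for an effect already at smaller amounts and higher numbers for an effect only at larger amounts of compound), compound 2 holds the lower of the two numbers (0.00767 mg/kg). Compound 3 carries 3-((carboxymethyl)sulfanyl)propyl in place of 5-carboxypent-1-en-1-yl on a saturated chain carbon bound to a saturated ring carbon. For the measured compounds named here, only one measured step bears on this change (a 4.2-fold lower number from compound 1 to compound 2 (0.62 log units; beyond the scatter)), and it introduced a chain double bond that compound 3 lacks. Going by the values given here, no measured compound carries the sulfur-containing chain, so a partial return towards the higher number is expected (a 2.6-fold higher number from compound 2 to compound 3 (0.42 log units; beyond the scatter)). The estimated value for compound 3 is 0.02 mg/kg (range 0.005 mg/kg to 0.08 mg/kg).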

Compound 3, dose for half-maximal effect: 0.171 mg/kg
Compound 3: the middle estimate sits 8.6-fold (0.93 log units) below what was measured; the whole stated range lies below it.
By their numbers in this assay, from the lowest: compound 2; then compound 1; then compound 3.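

In this assay, 3-((carboxymethyl)sulfanyl)propyl in place of 5-carboxypent-1-en-1-yl gives a 22-fold higher number from compound 2 to compound 3 (1.35 log units; beyond the scatter), so this end of the molecule is far less forgiving than the earlier pair showed. Even (carboxymethyl)sulfanyl in place of carboxymethyl gives a 5.3-fold higher number from compound 1 to compound 3 (0.73 log units; beyond the scatter), which leaves the sulfur-containing chain behind the saturated all-carbon chain as well as the unsaturated one. Nothing given here accounts for this rise. The compounds shown leave open whether the sulfur itself or the missing chain double bond matters more. On these data alone, how an ether oxygen or a sulfone in the sulfur's place would read also stays open.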